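The source may hold more compounds than are shown below. What is called first, only, known or untested is meant among the compounds shown, and "the series" means these compounds.

Measured in a functional assay on KB cells (Homo sapiens) for inhibition; a lower number here means that less compound is needed, a higher number that more compound is needed for the effect:
- compound 1 `C=CC1CN2CCC1C[C@H]2[C@H](OCc1cn([C@H]2C[C@H](n3cc(C)c(=O)[nH]c3=O)O[C@@H]2CO)nn1)c1ccnc2ccc(OC)cc12`: 2.1 ug/mL
- compound 2 `C=CC1CN2CCC1C[C@@H]2[C@@H](OCc1cn([C@H]2C[C@H](n3cc(C)c(=O)[nH]c3=O)O[C@@H]2CO)nn1)c1ccnc2ccc(OC)cc12`: 3.9 ug/mL

Compound 1 and compound 2 sit within the scatter of each other, so neither one leads: a 1.9-fold higher number from compound 1 to compound 2 (0.27 log units; within the scatter). Their only difference is stereochemical, at two stereocentres.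

Next is compound 3 `C=CC1CN2CCC1C[C@H]2[C@H](OCc1cn([C@H]2C[C@H](n3cc(C)c(=O)[nH]c3=O)O[C@@H]2CO)nn1)c1ccnc2ccccc12`, which keeps the configuration of compound 1 and changes the aromatic end, 6-methoxyquinolin-4-yl to quinolin-4-yl: hydrogen in place of methoxy on an aromatic carbon. In words, hydrogen replaces methoxy on an aromatic carbon.

Within the data shown here, the one measured step, a 1.9-fold higher number from compound 1 to compound 2 (0.27 log units; within the scatter), is a change of configuration and leaves the methoxy in place, so no measurement covers this replacement directly. That step offers only a weak hint that this assay responds little to change here. No direction can be argued from the data, and no shift beyond the scatter is expected, so the range stays wide. The expected step is a 1.2-fold higher number from compound 1 to compound 3 (0.09 log units; within the scatter). For compound 3 the estimated value is 2.6 ug/mL, with an expected range from 0.9 ug/mL to 7.5 ug/mL.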

Compound 3, concentration for half-maximal effect: > 100 ug/mL
Compound 3 was reported as a limit; the forecaster's own chance of this, stated with the estimate: 8%; middle value at least 38-fold (1.58 log units) away from the limit.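

In this assay, this place on the aromatic ring turns out to be far more sensitive than the earlier pair suggested: replacing methoxy with hydrogen gives a large step (an at least 47-fold higher number from compound 1 to compound 3 (1.67 log units; beyond the scatter)), whereas the change of configuration stays within the scatter (a 1.9-fold higher number from compound 1 to compound 2 (0.27 log units; within the scatter)). The value of compound 3 (> 100 ug/mL) is a limit of the assay and not a number. Nothing measured here accounts for the size of this step.

On these data alone, whether another group on this aromatic carbon, such as ethoxy, hydroxyl or an amine, would hold the value of compound 1 remains open. Also open, as far as these compounds go, is whether the same replacement in the configuration of compound 2 would give a step of similar size.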